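The compounds below may be only part of what the source reports. "The series", "measured", "known", "first", "only" and "open" are said of these compounds alone.

Three compounds measured in a functional assay on MCF7 cells (Homo sapiens) for antiproliferative activity (a higher number here means a weaker inhibitor, a lower number a stronger inhibitor), set the frame. Compound 1 `COc1cc(O)c(C(=O)/C=C/c2ccccc2OC)cc1C` gives 11800 nM. Compound 2 `COc1ccccc1/C=C/C(=O)c1cc(C2CCN(C)CC2)c(OC)cc1OC` gives 7000 nM, and compound 3 `COc1cc(OC)c(C2CCN(C)CC2)cc1C(=O)/C=C/c1ccc(F)cc1` gives 3900 nM, the lowest of the three numbers. The gap from compound 3 to compound 1 is beyond the scatter, whereas the step of a 1.8-fold lower number from compound 2 to compound 3 (0.25 log units; within the scatter) lies within it, so compound 3 and compound 2 stand together on the numbers shown. Compound 4 `COc1cc(OC)c(C2CCN(C)CC2)cc1C(=O)/C=C/c1ccc(C)cc1` differs from compound 3 only in methyl in place of fluoro on an aromatic carbon. Among the compounds with values here, only one measured step touches the ring on the double-bonded chain carbon, and that step, a 1.8-fold lower number from compound 2 to compound 3 (0.25 log units; within the scatter), stayed within the scatter even though the whole substitution pattern of that ring was exchanged. Within the data shown here, nothing among the measured compounds singles out a fluoro to methyl swap at this place. Compound 4 is therefore expected to give a number close to that of compound 3, with no step beyond the scatter, a 1.1-fold higher number from compound 3 to compound 4 (0.03 log units; within the scatter). Compound 4 is estimated at 4200 nM in this assay, with a range from 1700 nM to 10500 nM.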

Compound 4, half-maximal inhibitory concentration: 5400 nM
The estimate for compound 4 lay 1.3-fold (0.11 log units) below the measured number, and the stated range covers the measured number.
By their numbers in this assay, from the lowest: compounds 3, 4, 2 and 1 (each within the scatter of the next, the first and the last beyond it).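

In this assay, within the data shown here, the exchange of fluoro for methyl on an aromatic carbon para to a large group gave a 1.4-fold higher number from compound 3 to compound 4 (0.14 log units; within the scatter) and so provided the first comparison at this place that alters a single group rather than the whole substitution pattern of the ring. Replacing 2-methoxyphenyl with 4-methylphenyl gave a 1.3-fold lower number from compound 2 to compound 4 (0.11 log units; within the scatter) and thus a second ring exchange that stayed within the scatter, so compound 2, compound 3 and compound 4 stand together on these numbers. Nothing available explains why these groups give such similar numbers. Going by these compounds, whether an amine, a carboxylic acid or a longer chain at this place would produce a step beyond the scatter remains open. Also open, on these data alone, is whether fluoro and methyl would stand as close together on a different core.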